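This account rests on a few compounds, and the source may have more. Where it says the series, first, only, none or still open, it means among the compounds named here.

Measured compounds:
Compound 1, `COC(=O)c1nc(C)n(-c2cccc(Br)c2)n1`: in a functional assay on NPC-TW01 cells (Homo sapiens) for inhibition, read by MTT assay, with a stated time of 72 h (a higher number here means a weaker inhibitor of growth, a lower number a stronger inhibitor of growth), compound 1 gives > 100000 nM, which is a limit of the assay rather than a number.
Compound 2, `COC(=O)c1nc(C)n(-c2ccc(C(F)(F)F)cc2)n1`: in this assay compound 2 gives > 100000 nM, again a limit rather than a number.
Compound 3, `COC(=O)c1nc(C)n(-c2ccc(F)cc2)n1`: in this assay compound 3 gives 15200 nM.

Within the data shown here, compound 3 thus stands as the only real number among the three; the other two sit at the limit of > 100000 nM in this assay, at which 2 of the 3 values shown sit. Among the measured compounds shown here, the single measured step, an at least 6.5-fold lower number from compound 2 to compound 3 (0.81 log units; beyond the scatter), concerns a group on the aryl ring and says nothing about the position altered next.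

Compound 4, `COC(=O)c1nc(C2CCCC2)n(-c2ccc(F)cc2)n1`, differs from compound 3 by cyclopentyl in place of methyl on an aromatic carbon. For the measured compounds named here, no measured step touches this position, so the size and direction of the change are open, and the expectation rests mainly on compound 3 itself. The estimated step is a 1.5-fold lower number from compound 3 to compound 4 (0.18 log units; within the scatter), with wide uncertainty. Compound 4 is therefore expected to give about 10000 nM in this assay, within a range from 2000 nM to 60000 nM.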

Compound 4, concentration for 50% growth inhibition: 10400 nM
For compound 4 the middle estimate is 1.0-fold (0.02 log units) below the measured one, within the range that was stated.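

In this assay, among these compounds, the exchange of methyl for cyclopentyl gives a 1.5-fold lower number from compound 3 to compound 4 (0.16 log units; within the scatter), so compound 3 and compound 4 cannot be told apart, and this is the first measured reading at this position. A much larger carbon group, carrying a ring of its own, can therefore stand on this aromatic carbon between two ring nitrogen atoms while growth inhibition stays at the level of compound 3. Compound 4 also gives a real number and does not join the compounds that show only a limit: the limit of > 100000 nM in this assay, at which 2 of the 4 values shown sit.

Only methyl and cyclopentyl stand at this position among the compounds shown, so the outcome with an amine, a phenyl ring or a longer chain there remains open. Also open, as far as these compounds go, is how a carboxylic acid in place of the methoxycarbonyl group would read on either compound.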